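A few compounds are considered here, and "the series" means these few. Any claim that something is new, unique, unknown or untested is made for them only; others in the source may bear on it.

Measured so far:
compound 1 `Cc1noc(NS(=O)(=O)c2cccc3c(N(C)C)cccc23)c1-c1ccccc1` — 15900 nM
compound 2 `Cc1noc(NS(=O)(=O)c2cccc3c(N4CCCCC4=O)cccc23)c1C` — 270 nM

In an assay on VSM-A10 cells for antagonist activity at Endothelin-1 receptor (Rattus norvegicus) (a higher number here means a weaker inhibitor, a lower number a stronger inhibitor), compound 2 gives the lower of the two numbers; compound 1 stands a higher value away, a gap beyond the scatter, though the two structures differ in more than one place.

Compound 3 `Cc1noc(NS(=O)(=O)c2cccc3c(NCc4ccccc4)cccc23)c1C` is not yet measured. It carries benzylamino in place of 2-oxopiperidin-1-yl on an aromatic carbon. Among the compounds with values here, no measured pair shows this exchange, so its effect is unknown; a moderate loss against compound 2 is expected, beyond the scatter but uncertain in size. The estimated step of a 2.6-fold higher number from compound 2 to compound 3 (0.41 log units; beyond the scatter) gives compound 3 an expected value of 700 nM, with a range from 150 nM to 3500 nM.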

Compound 3, half-maximal inhibitory concentration: 590 nM
Estimate against measurement, compound 3: 1.2-fold (0.07 log units) above, and the stated range covers the measured number.
By their numbers in this assay, from the lowest: compound 2; then compound 3; then compound 1.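

On an aromatic carbon of the shared core, benzylamino in place of 2-oxopiperidin-1-yl gives only a modest change in this assay, with a 2.2-fold higher number from compound 2 to compound 3 (0.34 log units; beyond the scatter). Within the data shown here, this place therefore carries either a non-aromatic ring with a carbonyl or a carbon-only aromatic ring on a nitrogen-bearing group, and the hydrogen-bond donor that enters with benzylamino comes with no large step. No measurement here accounts for this step.

Open, on these data alone, is how a piperidin-1-yl group, lacking the carbonyl, or an N-methylbenzylamino group, lacking the amine hydrogen, would read at this place.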